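The compounds below may be only part of what the source reports. "The series", "measured", "known", "first", "only" and "open" are said of these compounds alone.

In an ADME assay on microsomes from liver (Homo sapiens) for metabolic stability, read by LC-MS, using NADPH, with a stated time of 60 min, tested at 0.1 uM (on this read-out higher numbers stand for a more stable compound and lower numbers for a less stable compound), two compounds have been measured so far. Compound 1 `Fc1ccc(Nc2cc3[nH]c(Nc4ccc(N5CCNCC5)cn4)nc3cn2)cc1F` carries piperazin-1-yl and stands at 92% on this read-out. Compound 2 `C[C@@H]1CN(c2ccc(Nc3nc4cnc(Nc5ccc(F)c(F)c5)cc4[nH]3)nc2)C[C@H](C)N1` carries 3,5-dimethylpiperazin-1-yl and stands at 63% as the lower of the two numbers. Compound 3 `Fc1ccc(Nc2cc3[nH]c(Nc4ccc(C5CCNCC5)cn4)nc3cn2)cc1F` is the next structure, and the change from compound 2 is piperidin-4-yl in place of 3,5-dimethylpiperazin-1-yl on an aromatic carbon on an aromatic carbon of a six-membered aromatic ring with 1 nitrogen. Among the measured compounds shown here, the one measured step that bears on this change is a number 29 percentage points lower from compound 1 to compound 2 (beyond the scatter) and it is modest but beyond the scatter, with 3,5-dimethylpiperazin-1-yl in place of piperazin-1-yl. For the measured compounds named here, no measured compound carries piperidin-4-yl, so the entering group is untested here. Compound 3 does give up the group found in compound 2 at 63% on this read-out, and so an upward move towards compound 1 at 92% is expected, though perhaps not all the way. The expected step is a number 17 percentage points higher from compound 2 to compound 3 (beyond the scatter) as an estimate. For compound 3 the estimated value is 80% with an expected range from 62% to 93% in this measurement.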

Compound 3, percent of the compound remaining in the Homo sapiens assay: 98%
For compound 3 the middle estimate is 18 percentage points below the measured one, and the stated range ends below it.
By their numbers in the Homo sapiens assay, from the lowest: compound 2; then compounds 1 and 3 (each within the scatter of the next).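

In the Homo sapiens assay, the step of a number 35 percentage points higher from compound 2 to compound 3 (beyond the scatter) shows that this position, on an aromatic carbon of a six-membered aromatic ring with 1 nitrogen and para to a large group, can take a ring other than a piperazine with a large gain relative to compound 2 at 63%, with compound 3 at 98%. In the Homo sapiens assay, the step of a number 6 percentage points higher from compound 1 to compound 3 (within the scatter) leaves piperidin-4-yl and piperazin-1-yl level, so that among these three compounds only 3,5-dimethylpiperazin-1-yl stands apart, which the earlier pair alone could not show. In a physicochemical assay for solubility, read by HPLC, using the shake flask method, in phosphate buffer, measured as kinetic solubility, with a stated time of 20 h, at pH 6.5 (a lower number here means a less soluble compound, a higher number a more soluble compound), compound 2 gives 175000 nM and compound 3 gives 190000 nM, and the step of a 1.1-fold higher number from compound 2 to compound 3 (0.04 log units; within the scatter) shows no separation between the two groups, so the change that moves the number so strongly in the Homo sapiens assay does not move the number in the physicochemical assay.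

Nothing given here accounts for these differences. From the compounds shown here alone, it remains open whether a single methyl on the piperazin-1-yl ring would already bring the lower number of compound 2, and whether a methyl group on the nitrogen of piperidin-4-yl, or a hydroxyl on that ring, would keep the level shared by compound 1 and compound 3.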